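A second chloro on compound 2

The source may report more compounds than this note shows. Statements on the series, on what has been measured and on what is new or still open speak of the compounds shown alone.

- compound 1 `O=S1(=O)C=Cc2ccc(Nc3ccc(C(F)(F)F)cc3)cc21` gives 1140 nM
- compound 2 `O=S1(=O)C=Cc2ccc(Nc3ccc(Cl)cc3)cc21` gives 2300 nM

Among the compounds with values here, in a functional assay on A549 cells (Homo sapiens) for antiproliferative activity, read by MTT assay, with a stated time of 72 h (on this read-out lower numbers stand for stronger inhibition and higher numbers for weaker inhibition), compound 2 stands within the scatter of compound 1 , the only other measured compound. Compound 3 `O=S1(=O)C=Cc2ccc(Nc3ccc(Cl)c(Cl)c3)cc21` differs from compound 2 by chloro in place of hydrogen on an aromatic carbon, ortho to a chloro group. Within the data shown here, one measured step bears on this, a 2.0-fold higher number from compound 1 to compound 2 (0.30 log units; within the scatter), and it exchanges trifluoromethyl for chloro rather than adding a group. Among the measured compounds shown here, with only that step to go on, no change beyond the scatter is expected in this assay, and no firm direction. The estimated step is a 1.4-fold lower number from compound 2 to compound 3 (0.13 log units; within the scatter). Compound 3 is expected at 1700 nM, with an estimated range of 700 nM to 4000 nM.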

Compound 3, half-maximal inhibitory concentration: 3320 nM
The estimate for compound 3 lay 2.0-fold (0.29 log units) below the measured number, within the range that was stated.
By their numbers in this assay, from the lowest: compounds 1, 2 and 3 (each within the scatter of the next, the first and the last beyond it).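

In this assay, the added chloro, ortho to a chloro group, is the first step among these compounds that puts a group in place of hydrogen, and it gives a 1.4-fold higher number from compound 2 to compound 3 (0.16 log units; within the scatter). This position on the aromatic ring therefore takes a chloro with no change beyond the scatter, something the exchange of trifluoromethyl for chloro could not show. Nothing at hand speaks to the reason for this result. The compounds shown leave open whether a methoxy, an amine or a carboxylic acid at this place would shift the number beyond the scatter.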